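The source may hold more compounds than are shown below. What is called first, only, known or untested is meant among the compounds shown, and "the series" means these compounds.

Series notes. In a functional assay on L1210 cells (Mus musculus) for cytotoxicity, read by cell counting, with a stated time of 2 days (a lower number here means a stronger inhibitor, a higher number a weaker inhibitor), compound 1 `C=C(Br)C(=O)Nc1ccc(/C=C2\SC(=O)N(Cc3ccc(C)cc3)C2=O)cc1` gives 3400 nM, compound 2 `C=C(Br)C(=O)Nc1ccc(/C=C2\SC(=O)N(Cc3ccccc3)C2=O)cc1` gives 1100 nM and compound 3 `C=C(Br)C(=O)Nc1ccc(/C=C2\SC(=O)N(Cc3ccc(F)cc3)C2=O)cc1` gives 2200 nM. Among the compounds with values here, compound 3 stands second highest of the three numbers, with a 1.5-fold lower number from compound 1 to compound 3 (0.19 log units; within the scatter) and a 2.0-fold higher number from compound 2 to compound 3 (0.30 log units; within the scatter) both within the scatter, whereas a 3.1-fold lower number from compound 1 to compound 2 (0.49 log units; beyond the scatter) is the one step beyond it. Compound 4 `C=C(Br)C(=O)Nc1ccc(/C=C2\SC(=O)N(Cc3ccc(Cl)cc3)C2=O)cc1` differs from compound 3 by chloro in place of fluoro on an aromatic carbon. The two measured steps that exchange the same group and arrive at compound 3 both stayed within the scatter, so for compound 4 in this assay no step beyond the scatter is expected in either direction. The estimate for compound 4 is 2500 nM (range 1000 nM to 6000 nM), and the expected step is a 1.1-fold higher number from compound 3 to compound 4 (0.06 log units; within the scatter).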

Compound 4, half-maximal inhibitory concentration: 3400 nM
Compound 4: the middle estimate sits 1.4-fold (0.13 log units) below what was measured; the range from low to high includes it.
By their numbers in this assay, from the lowest: compounds 2, 3, 1 and 4 (each within the scatter of the next, the first and the last beyond it).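

In this assay, chloro on this aromatic carbon, para to a large group, stays within the scatter of fluoro, with a 1.5-fold higher number from compound 3 to compound 4 (0.19 log units; within the scatter) as the step, and of methyl, with no change at the digits printed from compound 1 to compound 4 (within the scatter) as the step. Set against hydrogen, chloro gives a 3.1-fold higher number from compound 2 to compound 4 (0.49 log units; beyond the scatter) and so joins methyl beyond the scatter, while compound 3 with fluoro goes against that pattern by staying within it. No measurement shown gives a cause for these steps.

Left open is how an amine, a carboxylic acid or a methoxy group on this same carbon would compare with hydrogen. The compounds shown vary only this one place, so nothing can be read about the rest of the shared core.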